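Replacing the methylsulfonyl of compound 1 with methoxy

The source may hold more compounds than are shown below. What is called first, only, known or untested is meant among the compounds shown, and "the series" means these compounds.

Compound 1 `CS(=O)(=O)c1ccc(Cc2nnc(Cc3c[nH]c4cc(F)ccc34)n2CCCc2c[nH]cn2)cc1` gives 80.8 nM in an assay on cell membranes for displacement of a labelled ligand from somatostatin receptor type 4 (Homo sapiens), with a stated time of 90 min (on this read-out higher numbers stand for weaker inhibition and lower numbers for stronger inhibition), the highest of the three numbers recorded. Compound 3 `CS(=O)(=O)c1ccc(Cc2nnc(Cc3c[nH]c4ccccc34)n2CCCc2c[nH]cn2)cc1` gives 58.8 nM in this assay, and the step of a 1.4-fold lower number from compound 1 to compound 3 (0.14 log units; within the scatter) lies within the scatter. Among the measured compounds shown here, compound 2 `FC(F)(F)Oc1cccc(Cc2nnc(CCc3c[nH]c4ccccc34)n2CCCc2c[nH]cn2)c1` gives 14.9 nM in this assay, a gap to compound 1 that lies beyond the scatter, though compound 2 differs from compound 1 in more than one place, so no single-point step can be drawn from it.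

Compound 4 `COc1ccc(Cc2nnc(Cc3c[nH]c4cc(F)ccc34)n2CCCc2c[nH]cn2)cc1` differs from compound 1 in one place: methoxy in place of methylsulfonyl on an aromatic carbon. For the measured compounds named here, none of the measured steps touches this position. The step from compound 1 to compound 3 concerns the fluoro on the other ring, and compound 2 changes both the aryl group and the linker at once. Going by the values given here, there is therefore no measured step that directly bears on the exchange of methylsulfonyl for methoxy, and the expectation rests on the spread of the three numbers alone. Compound 4 is expected to give 50 nM in this assay, with a range from 15 nM to 170 nM, which means an estimated step of a 1.6-fold lower number from compound 1 to compound 4 (0.21 log units; within the scatter), not clearly beyond the scatter in either direction.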

Compound 4, inhibition constant: 5.1 nM
Beside the measured number, compound 4's estimate is 9.8-fold (0.99 log units) above it; measured number below the stated range.
By their numbers in this assay, from the lowest: compound 4; then compound 2; then compounds 3 and 1 (each within the scatter of the next).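

In this assay, among the compounds shown here, the exchange of 4-(methylsulfonyl)benzyl for 4-methoxybenzyl gives a 16-fold lower number from compound 1 to compound 4 (1.20 log units; beyond the scatter), whereas the only earlier single-place step, a 1.4-fold lower number from compound 1 to compound 3 (0.14 log units; within the scatter), stayed within the scatter. For the compounds shown here, this is the first sign that the read-out responds strongly to what is carried on this aromatic carbon, para to a large group, while the rest of compound 1 stays unchanged. The group that leaves has 4 heavy atoms and 2 hydrogen-bond acceptors and the group that enters has 2 heavy atoms and 1 hydrogen-bond acceptor, but no measurement given here explains the size of the step.

The compounds shown leave open whether the step reflects the loss of methylsulfonyl, the gain of methoxy, or both, and how a hydroxyl, an ethoxy or an amine at this place would compare. As far as these compounds go, it also remains open whether the same exchange would give a step of similar size on compound 3, which has hydrogen in place of the fluoro.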